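The compounds below may be only part of what the source reports. "The series", "measured", "known", "first", "only" and "open" are said of these compounds alone.

Measured so far in a functional assay on MCF7 cells (Homo sapiens) for cytotoxicity, read by MTT assay, with a stated time of 96 h; a higher number here means a weaker inhibitor, a lower number a stronger inhibitor:
compound 1, `COc1cc(C(=O)c2cn(-c3cccc(C)c3)cc2-c2ccccc2F)cc(OC)c1OC`, gives 190 nM
compound 2, `COc1cc(C(=O)c2cn(-c3cccc(C)c3)cc2-c2ccccc2Cl)cc(OC)c1OC`, gives 420 nM
compound 3, `COc1cc(C(=O)c2cn(-c3ccc(F)cc3)cc2-c2ccccc2F)cc(OC)c1OC`, gives 39 nM

Compound 3 stands lowest of the three numbers. Its nearest neighbour is compound 1, and the step between them reads a 4.9-fold lower number from compound 1 to compound 3 (0.69 log units; beyond the scatter). Compound 2 lies furthest from compound 3 within the measured set.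

The one change that is made twice among the compounds shown is the move from compound 1 to compound 2, (chloro in place of fluoro on an aromatic carbon), which gave a 2.2-fold higher number from compound 1 to compound 2 (0.34 log units; beyond the scatter).

Compound 4, `COc1cc(C(=O)c2cn(-c3ccc(F)cc3)cc2-c2ccccc2Cl)cc(OC)c1OC`, is still to be measured in this assay. It differs from compound 3 by chloro in place of fluoro on an aromatic carbon. The two cores on which this change is made differ from one another by 4-fluorophenyl in place of 3-methylphenyl on an aromatic nitrogen. For the measured compounds named here, the description of the place is the same word for word in both cases, so the change from compound 3 to compound 4 is taken as the same change as the one from compound 1 to compound 2.

Because the earlier instance gave a 2.2-fold higher number from compound 1 to compound 2 (0.34 log units; beyond the scatter), the new step is expected to come out as a 2.2-fold higher number from compound 3 to compound 4 (0.34 log units; beyond the scatter), a step of about the same size and direction, moving off the lowest value in the set. This rests on a single prior pair only. Compound 4 is therefore estimated to give about 86 nM in this assay. The expected range for compound 4 runs from 40 nM to 190 nM.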

Compound 4, half-maximal inhibitory concentration: 83 nM
Beside the measured number, compound 4's estimate is 1.0-fold (0.02 log units) above it, within the range that was stated.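

In this assay, chloro in place of fluoro on an aromatic carbon gave a 2.1-fold higher number from compound 3 to compound 4 (0.33 log units; beyond the scatter), and the same change on a second core gave a step of matching size and direction: the same change on two cores in this assay, a 2.2-fold higher number (0.34 log units; beyond the scatter) from compound 1 to compound 2 and a 2.1-fold higher number (0.33 log units; beyond the scatter) from compound 3 to compound 4, 1.0-fold (0.02 log units) apart, within the scatter of two such steps. The other change in the set, 4-fluorophenyl in place of 3-methylphenyl on an aromatic nitrogen, also carried over, giving a 5.1-fold lower number from compound 2 to compound 4 (0.70 log units; beyond the scatter) with chloro in place and a matching step with fluoro in place: the same change on two cores in this assay, a 4.9-fold lower number (0.69 log units; beyond the scatter) from compound 1 to compound 3 and a 5.1-fold lower number (0.70 log units; beyond the scatter) from compound 2 to compound 4, 1.0-fold (0.02 log units) apart, within the scatter of two such steps. Within these four compounds the two changes therefore behave independently of one another, but this rests on two cores and two pairs of groups in a single cell assay, and it does not show that either step would hold on a core carrying any other substituent.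

Still open, as far as these compounds go, is how the series responds to groups of a different kind on the aromatic carbon ortho to a large group, such as methoxy, nitrile, an amine or a carboxylic acid, and whether the step seen for chloro and fluoro would persist alongside them. Equally open, from the compounds shown here alone, is what happens on the aromatic nitrogen when an aryl group gives way to a longer alkyl chain, and whether the same independence would survive that change.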